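Swapping the aryl group on the shared core

The source may report more compounds than this note shows. Statements on the series, on what has been measured and on what is new or still open speak of the compounds shown alone.

In a functional assay on Ehrlich cells (Mus musculus) for cytotoxicity, tested at 100 ug/mL (a higher number here means a stronger effect of the compound at the concentration tested, a lower number a weaker effect), compound 1 `COc1cc(N2C(N)=C(C#N)C(c3ccc([N+](=O)[O-])cc3)C3=C2CC(C)(C)CC3=O)cc(OC)c1OC` gives 80%, compound 2 `COc1cc(N2C(N)=C(C#N)C(c3c(OC)ccc4ccccc34)C3=C2CC(C)(C)CC3=O)cc(OC)c1OC` gives 30%, and compound 3 `COc1cc(N2C(N)=C(C#N)C(c3ccccc3O)C3=C2CC(C)(C)CC3=O)cc(OC)c1OC` gives 10%. Compound 3 thus stands lowest of the three, with compound 2 nearest and compound 1 furthest away. The step to compound 4 `COc1cc(N2C(N)=C(C#N)C(c3ccc(Cl)cc3Cl)C3=C2CC(C)(C)CC3=O)cc(OC)c1OC` changes the same position again: 2,4-dichlorophenyl in place of 2-hydroxyphenyl on a saturated ring carbon. Within the data shown here, two measured steps bear on it, and both are reversals of exchanges at this saturated ring carbon: a number 70 percentage points lower from compound 1 to compound 3 (beyond the scatter) and a number 20 percentage points lower from compound 2 to compound 3 (beyond the scatter). Read from compound 3 outward, each replacement of 2-hydroxyphenyl by another aryl group so far raised the read-out, by a large amount in one case and a modest amount in the other. A rise in this assay is therefore expected for compound 4, though its size is uncertain, since 2,4-dichlorophenyl has not been tried on this core. Compound 4 is estimated at 45%, within a range from 10% to 80%, which means an expected step of a number 35 percentage points higher from compound 3 to compound 4 (beyond the scatter).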

Compound 4, a percentage reported as activity, at one concentration (the size of the read-out at that concentration, not a potency): 100%
Beside the measured number, compound 4's estimate is 55 percentage points below it; the measured number lies above the stated range.
By their numbers in this assay, from the lowest: compound 3; then compound 2; then compound 1; then compound 4.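

Among the four aryl groups seen at this saturated ring carbon, 2,4-dichlorophenyl gives the highest read-out in this assay, with a number 90 percentage points higher from compound 3 to compound 4 (beyond the scatter) and a number 70 percentage points higher from compound 2 to compound 4 (beyond the scatter) and even a number 20 percentage points higher from compound 1 to compound 4 (beyond the scatter). So 4-nitrophenyl, the best group among the earlier compounds, did not mark the upper end at this position, and a group with two chlorines and no hydrogen-bond donor or acceptor now exceeds it. No measurement offered here explains why this group stands highest.

On these data alone, whether both chlorines are needed stays open, as does how a phenyl ring carrying an amine or a carboxylic acid would behave at this carbon. Since the read-out comes from a single concentration, the order of these compounds says nothing about their potency.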